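One Methoxy Less on a Weakly Cytotoxic Acid

The source may hold more compounds than are shown below. What is called first, only, known or untested is meant among the compounds shown, and "the series" means these compounds.

Compound 2 `COc1cc(/C(=C\c2cn(C(C)=O)c3ccc(OCc4ccccc4)cc23)C(=O)O)cc(OC)c1OC` — 89100 nM
Compound 1 `COc1ccc(/C(=C\c2c[nH]c3ccc(OCc4ccccc4)cc23)C(=O)O)cc1` — "not determined" (no result reported)

Within the data shown here, compound 2 carries the only number here: in a functional assay on A549 cells (Homo sapiens) for cytotoxicity, read by MTT assay, with a stated time of 72 h (on this read-out higher numbers stand for weaker inhibition and lower numbers for stronger inhibition), compound 2 gives 89100 nM. In this assay compound 1 gives "not determined" (no result reported), so nothing can be set beside compound 2. Compound 3 `COc1ccc(/C(=C\c2cn(C(C)=O)c3ccc(OCc4ccccc4)cc23)C(=O)O)cc1OC` differs from compound 2 by hydrogen in place of methoxy on an aromatic carbon. Among the measured compounds shown here, no step between measured compounds exists to gauge this change, so the move is expected to stay within the usual scatter, with no direction beyond it. Compound 3 is accordingly estimated at 100000 nM, between 30000 nM and 300000 nM. The expected step of a 1.1-fold higher number from compound 2 to compound 3 (0.05 log units; within the scatter) is small.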

Compound 3, half-maximal inhibitory concentration: 54800 nM
Compound 3: middle estimate off by 1.8-fold (0.26 log units), on the high side, and the stated range covers the measured number.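

In this assay, the change from 3,4,5-trimethoxyphenyl to 3,4-dimethoxyphenyl gives a 1.6-fold lower number from compound 2 to compound 3 (0.21 log units; within the scatter), the first step measured at this position. Methoxy on this aromatic carbon can thus give way to hydrogen without the reading leaving the usual scatter. No measurement shown bears on the reason for this result.

Going by these compounds, whether a hydroxyl group, an amine or a fluorine atom on this carbon would shift the number beyond the scatter remains open. So does the effect of the same change on the core of compound 1.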